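A few compounds are considered here, and "the series" means these few. Any claim that something is new, unique, unknown or untested is made for them only; others in the source may bear on it.

Working notes on the series in a functional assay on AGS cells (Homo sapiens) for antiproliferative activity, read by MTT assay, with a stated time of 48 h; on this read-out higher numbers stand for weaker inhibition of growth and lower numbers for stronger inhibition of growth. Compound 1 `COc1ccc(N(C)c2ncnc3[nH]cnc23)cc1` gives > 100000 nM, which is a limit and not a number. Compound 3 `COc1ccc(N(C)c2ncnc3c2ncn3Cc2cc(OC)c(OC)c(OC)c2)cc1` gives > 100000 nM, again a limit. For the measured compounds named here, compound 2 `COc1ccc(N(C)c2nc(Cl)nc3[nH]cnc23)cc1` gives 30000 nM, the only value so far that is a true number. Going by the values given here, the one measured step is an at least 3.3-fold lower number from compound 1 to compound 2 (0.52 log units; beyond the scatter).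

Compound 4 `COc1ccc(Cn2cnc3c(N(C)c4ccc(OC)cc4)nc(Cl)nc32)cc1` follows from compound 2 by this change: 4-methoxybenzyl in place of hydrogen on an aromatic nitrogen. Among the compounds with values here, no measured step isolates this change. Compound 3 also carries a group on that nitrogen but has no chloro, and it says little because of the limit of > 100000 nM in this assay, at which 2 of the 3 values shown sit. Compound 4 keeps the chloro that came with an at least 3.3-fold lower number from compound 1 to compound 2 (0.52 log units; beyond the scatter), so a modest move to a lower number in this assay is expected, with wide uncertainty in both directions. The expected size of the change is a 3.8-fold lower number from compound 2 to compound 4 (0.57 log units; beyond the scatter). For compound 4 the estimated value is 8000 nM, with an expected range of 1000 nM to 50000 nM.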

Compound 4, concentration for 50% growth inhibition: > 100000 nM
Compound 4: only a limit was reported; the forecaster's own chance of this, stated with the estimate: 15%; at least 12-fold (1.09 log units) between middle value and limit.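

In this assay, for the compounds shown here, 4-methoxybenzyl in place of hydrogen on an aromatic nitrogen gives an at least 3.3-fold higher number from compound 2 to compound 4 (0.52 log units; beyond the scatter), the first reading of this change on its own. Compound 3 carries a group on that nitrogen but has no chloro, so only compound 4 shows that keeping the chloro does not preserve the value of compound 2 once this group enters. Compound 4 gives > 100000 nM, which is a limit and not a number, so the full size of the step stays unknown: the limit of > 100000 nM in this assay, at which 3 of the 4 values shown sit.

Open, on these data alone, is whether a small group on that nitrogen, such as methyl, or a chain ending in an amine or a carboxylic acid would fare better than 4-methoxybenzyl. Compound 2 gives 30000 nM. Also open, as far as these compounds go, is whether an amine in place of the chloro would give a lower number than compound 2.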